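Pyridin-4-yl in Place of 4-Chlorophenyl on a Sulfonamide

A few compounds are considered here, and "the series" means these few. Any claim that something is new, unique, unknown or untested is made for them only; others in the source may bear on it.

Compound 1 `COc1ccc(Cl)cc1S(=O)(=O)Nc1cncc(-c2ccc(Cl)cc2)c1` carries a 4-chlorophenyl group, but in an assay on isolated protein for inhibition of alkaline phosphatase, tissue-nonspecific isozyme (Homo sapiens) (a higher number here means a weaker inhibitor, a lower number a stronger inhibitor), compound 1 stands as "not determined" (no result reported), so it cannot be placed on the scale at all. The only measured anchor is a close relative, compound 2 `COc1ccc(Cl)cc1S(=O)(=O)Nc1cnc2ccccc2c1`; in this assay compound 2 gives 4510 nM, a rather weak inhibition. Compound 3 `COc1ccc(Cl)cc1S(=O)(=O)Nc1cncc(-c2ccncc2)c1` is the unmeasured partner of compound 1 and differs from it in a single place: pyridin-4-yl in place of 4-chlorophenyl on an aromatic carbon. With no value for compound 1, the size of this step cannot be read from any measured pair. The expectation is a modest weakening in this assay, probably beyond the usual scatter but not dramatic, landing near the level of compound 2. Compound 3 is therefore expected to give about 8000 nM, with a plausible range from 2000 nM to 30000 nM.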

Compound 3, half-maximal inhibitory concentration: > 20000 nM
Compound 3: a limit, no number (the forecaster's own chance of this, stated with the estimate: 25%); at least 2.5-fold (0.39 log units) between middle value and limit.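

In this assay compound 3 gives > 20000 nM, which is a limit and not a number. Among the compounds shown here, compound 1 has no number either, so no step between compound 1 and compound 3 can be read. The compounds shown leave open how much pyridin-4-yl in place of 4-chlorophenyl changes the inhibition.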